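Putting an Aromatic Ring Back onto Compound 3

The source may hold more compounds than are shown below. What is called first, only, known or untested is meant among the compounds shown, and "the series" means these compounds.

Of the compounds shown here, three sharing one core have been measured in a functional assay on J774.A1 cells (Mus musculus) for inhibition, read by immunoassay, with a stated time of 12 h, tested at 30 uM; on this read-out lower numbers stand for less inhibition and higher numbers for more inhibition at the one concentration tested (going by the name of the read-out). Compound 1 `CC(C)c1ccc(COc2ccccc2C2CC(=O)c3ccccc3O2)cc1` gives 91.7%. Compound 2 `CCCCOc1ccccc1C1CC(=O)c2ccccc2O1` gives 42.5%, and compound 3 `COc1ccccc1C1CC(=O)c2ccccc2O1` gives 38.3%, the lowest of the three numbers, with compound 2 sitting within the scatter of it and compound 1 far above it.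

Compound 4 `O=C1CC(c2ccccc2OCc2cccc(F)c2)Oc2ccccc21` has not yet been measured. It differs from compound 3 by 3-fluorophenyl in place of hydrogen on a saturated chain carbon bound to an oxygen on an aromatic ring.

Among the measured compounds shown here, two measured steps bear on this change, and both remove an aromatic group from the same saturated chain carbon: a number 53.4 percentage points lower from compound 1 to compound 3 (beyond the scatter), and a number 49.2 percentage points lower from compound 1 to compound 2 (beyond the scatter). The step of a number 4.2 percentage points lower from compound 2 to compound 3 (within the scatter) shows that propyl and hydrogen at that carbon give numbers within the scatter of each other, so the large drop belongs to losing the aromatic ring. Restoring an aromatic ring at that carbon in compound 4 is therefore expected to bring a large rise, a number 41.7 percentage points higher from compound 3 to compound 4 (beyond the scatter). Compound 4 is estimated at 80%, within a range from 60% to 95%.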

Compound 4, a percentage reported as inhibition, at one concentration (the size of the read-out at that concentration, not a potency): 92.7%
For compound 4 the middle estimate is 12.7 percentage points below the measured one, and the stated range covers the measured number.
By their numbers in this assay, from the lowest: compounds 3 and 2 (each within the scatter of the next); then compounds 1 and 4 (each within the scatter of the next).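

In this assay, putting 3-fluorophenyl on this saturated chain carbon gives a number 54.4 percentage points higher from compound 3 to compound 4 (beyond the scatter) and, with propyl as the group replaced, a number 50.2 percentage points higher from compound 2 to compound 4 (beyond the scatter). The high number seen with 4-isopropylphenyl in compound 1 therefore also appears with a second, differently substituted aromatic ring, and exchanging one ring for the other gives a number 1 percentage points higher from compound 1 to compound 4 (within the scatter). Among these four compounds, the two with an aromatic ring at this carbon sit high and the two without one sit low, and none goes against this pattern.

Nothing available gives a reason for this rise. From the compounds shown here alone, it remains open whether a ring with nitrogen in it, such as pyridine, an amine or a longer chain at this carbon would keep the number high, and how compound 1 and compound 4 would compare at lower concentrations.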